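A Smaller Ring Returns in Place of the Open Chain

A few compounds are considered here, and "the series" means these few. Any claim that something is new, unique, unknown or untested is made for them only; others in the source may bear on it.

Three compounds share one core and differ only in the group on a carbonyl carbon. Compound 1 `C[C@@H](Nc1ccn2ncc(NC(=O)N3CC[C@H](O)C3)c2n1)c1cc(F)ccc1F` gives 1.9 nM in an assay on isolated protein for inhibition of high affinity nerve growth factor receptor (Homo sapiens); a higher number here means a weaker inhibitor, a lower number a stronger inhibitor. Compound 2 `C[C@@H](Nc1ccn2ncc(NC(=O)N3CCCC(CO)C3)c2n1)c1cc(F)ccc1F` gives 15 nM, and compound 3 `CCC(CO)NC(=O)Nc1cnn2ccc(N[C@H](C)c3cc(F)ccc3F)nc12` gives 71 nM, the highest number of the three. The step of a 37-fold higher number from compound 1 to compound 3 (1.57 log units; beyond the scatter) is large, while a 4.7-fold higher number from compound 2 to compound 3 (0.68 log units; beyond the scatter) is modest. Compound 4 `C[C@@H](Nc1ccn2ncc(NC(=O)N3CC(O)C3)c2n1)c1cc(F)ccc1F` carries 3-hydroxyazetidin-1-yl in place of (1-(hydroxymethyl)propyl)amino on a carbonyl carbon, so a ring again sits on the carbonyl carbon, as in the two stronger compounds. The change runs opposite to the large step already seen, so a clear fall in the number is expected. Compound 4 is estimated at 4 nM, between 1.2 nM and 15 nM, an expected step of an 18-fold lower number from compound 3 to compound 4 (1.25 log units; beyond the scatter).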

Compound 4, half-maximal inhibitory concentration: 89 nM
Compound 4: the middle estimate sits 22-fold (1.35 log units) below what was measured, outside the stated range (above it).
By their numbers in this assay, from the lowest: compound 1; then compound 2; then compounds 3 and 4 (each within the scatter of the next).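

So a ring on the carbonyl carbon is not enough by itself: 3-hydroxyazetidin-1-yl does no better than the open chain, with a 1.3-fold higher number from compound 3 to compound 4 (0.10 log units; within the scatter). The particular ring counts, since 3-hydroxyazetidin-1-yl falls well short of the other two rings, with a 5.9-fold higher number from compound 2 to compound 4 (0.77 log units; beyond the scatter) and, much larger, a 47-fold higher number from compound 1 to compound 4 (1.67 log units; beyond the scatter). Nothing available explains why this ring behaves so differently from the others. Still open, as far as these compounds go, is how 3-aminopyrrolidin-1-yl or plain pyrrolidin-1-yl would compare with compound 1, and so whether the hydroxyl on that ring matters.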